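Aryl swap on the amide-type nitrogen, compound 2 to compound 3

The source may report more compounds than this note shows. Statements on the series, on what has been measured and on what is new or still open speak of the compounds shown alone.

Compound 1 `Fc1ccccc1NC(=S)N/N=C/c1ccc2ccccc2n1` and compound 2 `Cc1cccc(NC(=S)N/N=C/c2ccc3ccccc3n2)c1` share one core and differ only in the aryl group on the amide-type nitrogen. In a functional assay on SGC-7901 cells (Homo sapiens) for antiproliferative activity, read by sulforhodamine B assay, with a stated time of 72 h (a lower number here means a stronger inhibitor, a higher number a weaker inhibitor), compound 1 gives only a limit, > 100000 nM. Compound 2 likewise gives only a limit in this assay, > 100000 nM. The step that the two limits leave unreadable from compound 1 to compound 2 therefore cannot be read, since both values sit at the limit (the limit of > 100000 nM in this assay, at which 2 of the 2 values shown sit). Compound 3 `N#Cc1ccc(NC(=S)N/N=C/c2ccc3ccccc3n2)cc1` is the next member: 4-cyanophenyl in place of 3-methylphenyl on an amide-type nitrogen. No measured step bears on this change; the one step shown, a step that the two limits leave unreadable from compound 1 to compound 2, is itself unreadable, so neither a direction nor a size can be drawn from it. For compound 3 the expectation is that this assay again reports a limit rather than a number, with the step of a number no higher from compound 2 to compound 3 (the limit leaves the size open) expected to be nil beyond the scatter. The estimate for compound 3 in this assay is 100000 nM, within 30000 nM to 300000 nM.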

Compound 3, half-maximal inhibitory concentration: 23700 nM
Compound 3: middle estimate off by 4.2-fold (0.63 log units), on the high side; the whole stated range lies above it.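

The aryl group on the amide-type nitrogen can move the read-out off the limit: in this assay, 4-cyanophenyl gives an at least 4.2-fold lower number from compound 2 to compound 3 (0.62 log units; beyond the scatter) and an at least 4.2-fold lower number from compound 1 to compound 3 (0.62 log units; beyond the scatter). Both steps have an open size, and the true gap may be larger, since each starts from a limit rather than a number. The step between compound 1 and compound 2 cannot be read, so 2-fluorophenyl and 3-methylphenyl cannot be ranked, and only compound 3 gives a number: the limit of > 100000 nM in this assay, at which 2 of the 3 values shown sit.

As far as these compounds go, whether the nitrile itself carries the step, or the 4-cyanophenyl group as a whole, stays open. Also open, from the compounds shown here alone, is how a plain phenyl, a 4-aminophenyl or a 4-carboxyphenyl group would read on this nitrogen.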